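This account rests on a few compounds, and the source may have more. Where it says the series, first, only, none or still open, it means among the compounds named here.

Measured so far in a functional assay on SMMC-7721 cells (Homo sapiens) for cytotoxicity, read by MTT assay, with a stated time of 48 h; a lower number here means a stronger inhibitor, a higher number a weaker inhibitor:
Compound 1 `CCN(CC)Cc1cc(Cl)cc2c(=O)cc(-c3ccc([N+](=O)[O-])cc3)oc12` gives 2990 nM
Compound 2 `O=c1cc(-c2ccc([N+](=O)[O-])cc2)oc2c(CN3CCCCC3)cc(Cl)cc12` gives 1090 nM
Compound 3 `CN(C)Cc1cc(Cl)cc2c(=O)cc(-c3ccc([N+](=O)[O-])cc3)oc12` gives 56500 nM

Compound 3 has the highest number of the three, which makes it the weakest inhibitor in this small set. The change to compound 4 `O=c1cc(-c2ccc([N+](=O)[O-])cc2)oc2c(Cn3ccnc3)cc(Cl)cc12` sits on a saturated chain carbon bound to an aromatic carbon and reads 1H-imidazol-1-yl in place of dimethylamino on a saturated chain carbon bound to an aromatic carbon on an otherwise shared core. Two measured steps at this same place bear on it: a 19-fold higher number from compound 1 to compound 3 (1.28 log units; beyond the scatter) and a 52-fold higher number from compound 2 to compound 3 (1.71 log units; beyond the scatter) are both large. The step of a 2.7-fold lower number from compound 1 to compound 2 (0.44 log units; beyond the scatter) is only modest. Neither diethylamino nor piperidin-1-yl is an aromatic ring, so this evidence carries over only loosely. A move toward a lower number is still expected, with a 7.1-fold lower number from compound 3 to compound 4 (0.85 log units; beyond the scatter) estimated in this assay for this change. Compound 4 is estimated at 8000 nM with a range from 1500 nM to 40000 nM expected.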

Compound 4, half-maximal inhibitory concentration: 1200 nM
For compound 4 the middle estimate is 6.7-fold (0.82 log units) above the measured one, outside the stated range (below it).
By their numbers in this assay, from the lowest: compounds 2 and 4 (each within the scatter of the next); then compound 1; then compound 3.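

In this assay, a five-membered aromatic ring is tolerated on this saturated chain carbon, and it brings a large gain over the small dimethylamino group: a 47-fold lower number from compound 3 to compound 4 (1.67 log units; beyond the scatter). Against the larger groups, the result is a 1.1-fold higher number from compound 2 to compound 4 (0.04 log units; within the scatter), so 1H-imidazol-1-yl and piperidin-1-yl cannot be told apart here, while the other comparison is a 2.5-fold lower number from compound 1 to compound 4 (0.40 log units; beyond the scatter). No measurement shown here explains these differences. Still open, as far as these compounds go, is whether morpholin-4-yl or 1H-pyrazol-1-yl on this carbon would read like compound 4 or like compound 3.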